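The source may report more compounds than this note shows. Statements on the series, on what has been measured and on what is new or still open speak of the compounds shown alone.

Compound 1, `COC(=O)c1scc(-c2ccc(NC(=O)c3ccccn3)cc2)c1OC`: > 50000 nM
Compound 2, `COC(=O)c1scc(-c2ccc(NC(=O)c3ccc(F)c(Cl)n3)cc2)c1OC`: 16200 nM

Compound 1 carries pyridin-2-yl on the carbonyl carbon. In a functional assay on HeLa cells (Homo sapiens) for antiproliferative activity, read by MTT assay, with a stated time of 24 h (a higher number here means a weaker inhibitor, a lower number a stronger inhibitor), compound 1 reaches only a limit and no number, > 50000 nM. Of the two values shown, one sits at a limit: the limit of > 50000 nM in this assay, at which 1 of the 2 values shown sits. Compound 2 carries 6-chloro-5-fluoropyridin-2-yl in the same place, and in this assay compound 2 gives 16200 nM, the only true number shown. Within the data shown here, the single measured step is an at least 3.0-fold lower number from compound 1 to compound 2 (0.48 log units; beyond the scatter).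

Compound 3 is `COC(=O)c1scc(-c2ccc(NC(=O)c3ccc(OC)nc3)cc2)c1OC`. It differs from compound 2 thus: 6-methoxypyridin-3-yl in place of 6-chloro-5-fluoropyridin-2-yl on a carbonyl carbon. Among the measured compounds shown here, the only step that bears on it points the other way: the halogenated pyridin-2-yl went with the stronger number in an at least 3.0-fold lower number from compound 1 to compound 2 (0.48 log units; beyond the scatter), and compound 3 gives up both halogens for a 6-methoxypyridin-3-yl. A step toward a weaker inhibitor, or none beyond the scatter, is therefore expected. Compound 3 is estimated at 35000 nM, in the range 12000 nM to 100000 nM, which is expected to be a 2.2-fold higher number from compound 2 to compound 3 (0.33 log units; beyond the scatter).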

Compound 3, half-maximal inhibitory concentration: 24400 nM
The estimate for compound 3 lay 1.4-fold (0.16 log units) above the measured number; the measured number falls inside the stated range.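

At this place on the carbonyl carbon, halogens are not required to move away from the unsubstituted pyridin-2-yl in this assay: 6-methoxypyridin-3-yl, which carries neither chlorine nor fluorine, gives an at least 2.0-fold lower number from compound 1 to compound 3 (0.31 log units; beyond the scatter). Exchanging one substituted ring for the other gives a 1.5-fold higher number from compound 2 to compound 3 (0.18 log units; within the scatter), so this assay does not separate the two. From the compounds shown here alone, compound 1 stands at a limit and not at a number, so the true size of any step from it remains unknown: the limit of > 50000 nM in this assay, at which 1 of the 3 values shown sits.

The compounds shown leave open whether the step from compound 1 follows the ring substituents or the change from pyridin-2-yl to pyridin-3-yl, as the two change together in compound 3. They also leave open how an amine or a carboxylic acid on the pyridine ring would read in this assay.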